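The compounds below may be only part of what the source reports. "The series", "measured", "known", "first", "only" and "open" are said of these compounds alone.

Measured so far in an assay on cells with melanin-concentrating hormone receptor 1 (Homo sapiens) as the target, read by radioligand binding; on this read-out higher numbers stand for weaker inhibition and lower numbers for stronger inhibition:
compound 1 `CCC(C)COc1cccc2ccc(N)nc12`: 36 nM
compound 2 `CCCCCOc1cccc2ccc(N)nc12`: 580 nM
compound 3 `CC(C)Oc1cccc2ccc(N)nc12`: 437 nM

Compound 3 stands second highest of these three numbers. Its value is barely apart from that of compound 2, as a 1.3-fold lower number from compound 2 to compound 3 (0.12 log units; within the scatter) falls within the scatter, but it lies far from compound 1, where a 12-fold higher number from compound 1 to compound 3 (1.08 log units; beyond the scatter) is a large step. Compound 4 `CC(C)=CCOc1cccc2ccc(N)nc12` has not yet been measured. It differs from compound 3 in one place: 3-methylbut-2-en-1-yl in place of isopropyl on an oxygen on an aromatic ring.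

For the measured compounds named here, two measured steps bear on this change. Going from isopropyl to the unbranched pentyl of compound 2 changes essentially nothing, given a 1.3-fold lower number from compound 2 to compound 3 (0.12 log units; within the scatter). Going instead to the 2-methylbutyl of compound 1, a chain of the same length that carries a methyl, gives a large drop in the number, given a 12-fold higher number from compound 1 to compound 3 (1.08 log units; beyond the scatter). Going by the values given here, the 3-methylbut-2-en-1-yl group entering in compound 4 is as long as pentyl and 2-methylbutyl and, like 2-methylbutyl, carries a methyl, though on a carbon bearing a double bond, for which no measured compound gives guidance. A lower number than compound 3 is therefore expected in this assay, of a size between those two precedents, estimated as a 2.9-fold lower number from compound 3 to compound 4 (0.46 log units; beyond the scatter). Compound 4 is accordingly expected to give about 150 nM, with a likely range from 40 nM to 550 nM.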

Compound 4, half-maximal inhibitory concentration: > 2000 nM
Compound 4: only a limit was reported (the forecaster's own chance of this, stated with the estimate: 2%); at least 13-fold (1.12 log units) between middle value and limit.
By their numbers in this assay, from the lowest: compound 1; then compounds 3 and 2 (each within the scatter of the next). At a limit, above all of these: compound 4.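

In this assay compound 4 gives > 2000 nM, which is a limit and not a number, so each step to it has only a minimum size: the limit of > 2000 nM in this assay, at which 1 of the 4 values shown sits.

Even so, an at least 4.5-fold higher number from compound 3 to compound 4 (0.66 log units; beyond the scatter) and an at least 3.4-fold higher number from compound 2 to compound 4 (0.53 log units; beyond the scatter) show that this place on the oxygen on an aromatic ring does not treat every chain alike, something the within-scatter pair of isopropyl and pentyl had not revealed. The widest gap, an at least 55-fold higher number from compound 1 to compound 4 (1.74 log units; beyond the scatter), shows that a methyl on a chain as long as 2-methylbutyl does not by itself bring the low number of compound 1, since the 3-methylbut-2-en-1-yl group also carries one.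

The compounds shown leave open whether the double bond or the different placement of the methyl groups separates compound 4 from compound 1, and a saturated 3-methylbutyl chain on the same oxygen would be needed to tell these apart. From the compounds shown here alone, how far the true value of compound 4 lies beyond its limit also remains unknown, so the full size of these steps stays open.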